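The source may hold more compounds than are shown below. What is called first, only, known or untested is meant among the compounds shown, and "the series" means these compounds.

Measured in a functional assay on cells (Prostatic carcinoma cell, Homo sapiens) for cytotoxicity, read by sulforhodamine B assay, with a stated time of 48 h; on this read-out higher numbers stand for weaker inhibition of growth and lower numbers for stronger inhibition of growth:
- compound 1 `COc1cc2c(cc1C)NC(=O)/C2=C/c1c(OC)nc2sc(C)cn12`: 18800 nM
- compound 2 `COc1nc2sc(C)cn2c1C=C1C(=O)N(C)c2ccccc21`: 12600 nM
- compound 3 `O=C1Nc2ccccc2C1=Cc1c(-c2ccncc2)nc2sccn12`: 1100 nM

Compound 1 belongs to the upper pair of these three numbers. Compound 2 lies within the scatter of it, while compound 3 is clearly lower, beyond the scatter.

The step of interest leads to compound 4 `COc1ccc2c(c1)/C(=C\c1c(OC)nc3sc(C)cn13)C(=O)N2`, with the change hydrogen in place of methyl on an aromatic carbon, ortho to a methoxy group. For the measured compounds named here, no measured pair isolates this change, so the data give no direct size for it. In this assay, from the compounds shown here alone, no step beyond the scatter is expected, and the direction remains open. Compound 3 at 1100 nM shows that much lower numbers occur in the series, so the range is left wider on the lower side.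

The expected change is a 1.3-fold lower number from compound 1 to compound 4 (0.13 log units; within the scatter). Compound 4 is estimated at 14000 nM, with an expected range of 4500 nM to 32000 nM.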

Compound 4, concentration for 50% growth inhibition: 380 nM
Estimate against measurement, compound 4: 37-fold (1.57 log units) above, and the stated range ends above it.
By their numbers in this assay, from the lowest: compound 4; then compound 3; then compounds 2 and 1 (each within the scatter of the next).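

In this assay, hydrogen in place of methyl on this aromatic carbon, ortho to a methoxy group, gives a 49-fold lower number from compound 1 to compound 4 (1.69 log units; beyond the scatter). For the compounds shown here, this is the first size available for the change, and it marks the position as highly sensitive to substitution: losing one carbon, with no change in the count of hydrogen-bond donors or acceptors and no net charge, moves the read-out well beyond the scatter. The data shown offer no measurement that explains the size of this step.

From the compounds shown here alone, whether any group other than hydrogen is tolerated at this carbon remains open, and fluorine, chlorine, ethyl or an amine there would test that. Also open, going by these compounds, is whether the same step appears when the neighbouring methoxy group is replaced by a hydroxyl group or by hydrogen.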